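The compounds below may be only part of what the source reports. "The series", "measured", "known", "first", "only" and "open" are said of these compounds alone.

Measured so far:
compound 1 `CCCCSC(=S)C1=C(Nc2ccc(Cl)cc2)CC(C)(C)CC1=O` — > 20 ug/mL
compound 2 `CCCCCCCCCCCSC(=S)C1=C(Nc2ccc(Cl)cc2)CC(C)(C)CC1=O` — > 20 ug/mL
compound 3 `CCCCSC(=S)C1=C(Nc2ccc(Br)cc2)CC(C)(C)CC1=O` — > 20 ug/mL

In a functional assay on PBMC cells (Homo sapiens) for inhibition, read by ELISA, with a stated time of 18 h (on this read-out lower numbers stand for stronger inhibition and higher numbers for weaker inhibition), compound 1 gives only a limit of the assay, > 20 ug/mL. Compound 2 also gives a limit of the assay, > 20 ug/mL. Compound 3 too reaches only a limit, > 20 ug/mL. The change from compound 1 to compound 2 is heptyl in place of hydrogen on a saturated chain carbon, four bonds along the chain from a sulfur; its step, a step that the two limits leave unreadable from compound 1 to compound 2, cannot be sized because both values sit at the limit of > 20 ug/mL in this assay, at which 3 of the 3 values shown sit. The cores of compound 1 and compound 3 differ by bromo in place of chloro on an aromatic carbon, with the step that the two limits leave unreadable from compound 1 to compound 3. Compound 4 `CCCCCCCCCCCSC(=S)C1=C(Nc2ccc(Br)cc2)CC(C)(C)CC1=O` carries the same change as before, (heptyl in place of hydrogen on a saturated chain carbon, four bonds along the chain from a sulfur), at the same place. In this assay the step from compound 3 to compound 4 is expected to be a step that the limit leaves unreadable from compound 3 to compound 4, resting on compound 1 and compound 2 both sitting at the limit of > 20 ug/mL in this assay, at which 3 of the 3 values shown sit. Compound 4 is therefore expected to give about 30 ug/mL, between 10 ug/mL and 80 ug/mL, most likely reported again only as a limit.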

Compound 4, half-maximal inhibitory concentration: > 20 ug/mL
Compound 4: no number, only a limit; the forecaster's own chance of this, stated with the estimate: 85%; the middle value does not contradict the limit.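

Compound 4 also reaches only a limit, > 20 ug/mL. Its steps from compound 3 and from compound 2 therefore cannot be read: the limit of > 20 ug/mL in this assay, at which 4 of the 4 values shown sit. The compounds shown leave open how strongly any of them inhibits, and whether either change alters that.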